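Adding a methoxy group to compound 3

This account rests on a few compounds, and the source may have more. Where it says the series, first, only, none or still open, it means among the compounds named here.

In a functional assay on V79 cells (Cricetulus griseus) for cytotoxicity, read by colony formation (on this read-out lower numbers stand for stronger inhibition and higher numbers for weaker inhibition), compound 3 `CC1CN(c2cc3c(cc2F)c(=O)c(C(=O)O)cn3C2CC2)CC(C)N1` gives > 500 ug/mL, which is a limit of the assay and not a number. Compound 4 `COc1c(N2CC(C)NC(C)C2)c(F)cc2c(=O)c(C(=O)O)cn(C3CC3)c12` differs from it by one change: methoxy in place of hydrogen on an aromatic carbon. Methoxy is already present in compound 1 `COc1c(N2CCC(C)(CN)C2)c(F)cc2c(=O)c(C(=O)O)cn(C3CC3)c12`, at 38 ug/mL, and in compound 2 `COc1c(N2CCNCC2)c(F)cc2c(=O)c(C(=O)O)cn(C3CC3)c12`, at 82 ug/mL. Among the measured compounds shown here, the only measured step, a 2.2-fold higher number from compound 1 to compound 2 (0.33 log units; beyond the scatter), is modest and leaves the methoxy in place, so no measured pair tests methoxy directly. Taking compound 2 at 82 ug/mL as the guide, a lower number is expected for compound 4, though the size of the change is uncertain. The expected change is an at least 5.0-fold lower number from compound 3 to compound 4 (0.69 log units; beyond the scatter). Compound 4 is estimated at 100 ug/mL, with an expected range of 30 ug/mL to 350 ug/mL.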

Compound 4, half-maximal inhibitory concentration: > 500 ug/mL
Compound 4: only a limit was reported; the forecaster's own chance of this, stated with the estimate: 15%; middle value at least 5.0-fold (0.69 log units) away from the limit.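

Whether methoxy in place of hydrogen changes anything cannot be read, because compound 3 and compound 4 both stand at a limit and not at a number: the limit of > 500 ug/mL in this assay, at which 2 of the 4 values shown sit. With methoxy kept, the ring amine group matters: 3,5-dimethylpiperazin-1-yl in place of piperazin-1-yl gives an at least 6.0-fold higher number from compound 2 to compound 4 (0.78 log units; beyond the scatter), and in place of 3-(aminomethyl)-3-methylpyrrolidin-1-yl it gives an at least 13-fold higher number from compound 1 to compound 4 (1.11 log units; beyond the scatter). Methoxy therefore does not bring the number under the limit when 3,5-dimethylpiperazin-1-yl is present.

Open, as far as these compounds go, is how hydrogen compares with methoxy alongside piperazin-1-yl. Also open, from the compounds shown here alone, is how an ethoxy group or an amine would behave on this aromatic carbon.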